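This account rests on a few compounds, and the source may have more. Where it says the series, first, only, none or still open, it means among the compounds named here.

For the measured compounds named here, compound 2 `CN(C(=O)CCCCCCCSc1nnc(Cc2nn(C)c(=O)c3ccccc23)n1C)c1ccc(Cl)cc1Cl` is the only compound with a number in an assay on isolated protein (Mus musculus) for inhibition of IL15-IL15 receptor (Homo sapiens), read by resazurin assay, with stated times of 30 min and 2.5 days (a higher number here means a weaker inhibitor, a lower number a stronger inhibitor), and there compound 2 gives 11900 nM. Compound 1 `Cn1c(Cc2nn(C)c(=O)c3ccccc23)nnc1SCCCCCCCC(=O)Nc1ccc(O)cc1` reaches only the upper limit of the assay, and in this assay compound 1 gives > 30000 nM. Going by the values given here, the one measured step, an at least 2.5-fold lower number from compound 1 to compound 2 (0.40 log units; beyond the scatter), swapped the (4-hydroxyphenyl)amino group on the carbonyl carbon for (2,4-dichlorophenyl)(methyl)amino. Compound 3 `Cn1c(Cc2nn(C)c(=O)c3ccccc23)nnc1SCCCCCCCC(=O)Nc1ccc(F)cc1F` is not yet measured; it differs from compound 2 by (2,4-difluorophenyl)amino in place of (2,4-dichlorophenyl)(methyl)amino on a carbonyl carbon. This partly undoes the measured step: the amide hydrogen returns, as in compound 1, while the ring keeps two halogens, though fluorine rather than chlorine. Among the compounds with values here, since the only measured change toward an amide hydrogen with a different ring pattern sits at a limit, (the limit of > 30000 nM in this assay, at which 1 of the 2 values shown sits), a move back toward weaker inhibition is expected, as a 1.8-fold higher number from compound 2 to compound 3 (0.27 log units; within the scatter). Compound 3 is therefore estimated at 22000 nM, in a range from 8000 nM to 60000 nM, with a real chance that this assay again reports only a limit.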

Compound 3, half-maximal inhibitory concentration: 2300 nM
The estimate for compound 3 lay 9.6-fold (0.98 log units) above the measured number, outside the stated range (below it).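

In this assay, putting (2,4-difluorophenyl)amino in place of (2,4-dichlorophenyl)(methyl)amino on the carbonyl carbon gives a 5.2-fold lower number from compound 2 to compound 3 (0.71 log units; beyond the scatter), so the return of the amide hydrogen does not by itself bring weaker inhibition. With the amide hydrogen kept, 2,4-difluorophenyl in place of 4-hydroxyphenyl on the amide-type nitrogen gives an at least 13-fold lower number from compound 1 to compound 3 (1.11 log units; beyond the scatter), which shows that the ring carried on this nitrogen strongly affects the reading. The value of compound 1 is a limit and not a number, so this step has no fixed size: the limit of > 30000 nM in this assay, at which 1 of the 3 values shown sits.

On these data alone, the step to compound 3 changes the halogens and removes the methyl on nitrogen together, so the share of each change stays open. As far as these compounds go, how 2,4-dichlorophenyl with the amide hydrogen kept, or 4-fluorophenyl, would read in this assay also remains open.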